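Dithiazole imines on pyrazole: methyl in place of phenyl

A few compounds are considered here, and "the series" means these few. Any claim that something is new, unique, unknown or untested is made for them only; others in the source may bear on it.

Measured in a functional assay on A-431 cells (Homo sapiens) for cytotoxicity, read by resazurin assay, with a stated time of 72 h; a higher number here means a weaker inhibitor, a lower number a stronger inhibitor:
compound 1 `Clc1nss/c1=N\c1cc(-c2ccccc2)n[nH]1` gives > 100000 nM, a limit of the assay.
compound 2 `Clc1nss/c1=N\c1cc(-c2ccccc2)nn1Cc1ccccc1` gives > 100000 nM, also a limit.

Compound 2 stands only at the assay limit. Within the data shown here, the one measured step, a step that the two limits leave unreadable from compound 1 to compound 2, cannot be read because both values sit at the limit of > 100000 nM in this assay, at which 2 of the 2 values shown sit.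

Compound 3 `Cc1cc(/N=c2\ssnc2Cl)n(Cc2ccccc2)n1` differs from compound 2 by methyl in place of phenyl on an aromatic carbon. No readable measured step bears on this change, so no step beyond the scatter in this assay is expected in either direction. Compound 3 is therefore expected at 150000 nM, within 50000 nM to 500000 nM, most likely reported again as a limit. The step implied by this estimate, a step that the limit leaves unreadable from compound 2 to compound 3, is expected to lie within the scatter.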

Compound 3, half-maximal inhibitory concentration: 27000 nM
The estimate for compound 3 lay 5.6-fold (0.74 log units) above the measured number; the measured number lies below the stated range.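

Methyl in place of phenyl on the aromatic carbon gives an at least 3.7-fold lower number from compound 2 to compound 3 (0.56 log units; beyond the scatter) and shows that this position responds to its substituent. Compound 3 at 27000 nM is the only compound shown with a number rather than a limit. The step has no upper bound, because compound 2 stands at a limit: the limit of > 100000 nM in this assay, at which 2 of the 3 values shown sit.

On these data alone, whether methyl has the same effect with hydrogen in place of benzyl on the ring nitrogen stays open. Also open, as far as these compounds go, is how an ethyl group, a longer chain or an amine on this carbon would compare.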